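The source may report more compounds than this note shows. Statements on the series, on what has been measured and on what is new or still open speak of the compounds shown alone.

Working notes on the urea series. Three compounds have numbers in a functional assay on A-431 cells (Homo sapiens) for antiproliferative activity, read by MTT assay, with a stated time of 72 h (a higher number here means a weaker inhibitor, a lower number a stronger inhibitor), so far. Compound 1 `CN1CCN(Cc2ccc(NC(=O)Nc3ccc4ncnc(Nc5ccc(F)c(Cl)c5)c4c3)cc2)CC1` gives 4000 nM and stands highest of the three. Compound 2 `CN(C)Cc1ccc(NC(=O)Nc2ccc3ncnc(Nc4cccc(C(F)(F)F)c4)c3c2)cc1` gives 1030 nM and compound 3 `C#Cc1cccc(Nc2ncnc3ccc(NC(=O)Nc4ccc(CN(CC)CC)cc4)cc23)c1` gives 1240 nM in this assay; both gaps to compound 1 lie beyond the scatter. None of these pairs differs in a single place, so no step can be read between them.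

The step under consideration goes from compound 1 to compound 4 `C[C@@H](Nc1ncnc2ccc(NC(=O)Nc3ccc(CN4CCN(C)CC4)cc3)cc12)c1ccccc1`: 1-phenylethyl in place of 3-chloro-4-fluorophenyl on a nitrogen on an aromatic ring. Within the data shown here, no measured pair shows this kind of exchange, so its size is unknown; the shared core and the urea tail are kept. The expectation for compound 4 in this assay is a step of a 1.1-fold higher number from compound 1 to compound 4 (0.05 log units; within the scatter), that is, nothing clearly beyond the scatter in either direction. Compound 4 is estimated at 4500 nM, in the range 1500 nM to 15000 nM.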

Compound 4, half-maximal inhibitory concentration: > 10000 nM
Compound 4: a limit, no number; the forecaster's own chance of this, stated with the estimate: 10%; at least 2.2-fold (0.34 log units) between middle value and limit.
By their numbers in this assay, from the lowest: compounds 2 and 3 (each within the scatter of the next); then compound 1. At a limit, above all of these: compound 4.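

In this assay compound 4 reads > 10000 nM as a limit of the assay, not a number. Among these compounds, this is the only step read in one place, and it is a loss: 1-phenylethyl in place of 3-chloro-4-fluorophenyl on a nitrogen on an aromatic ring gives an at least 2.5-fold higher number from compound 1 to compound 4 (0.39 log units; beyond the scatter) in this assay. The group on this nitrogen therefore matters for the read-out, though the step has a lower bound only: the limit of > 10000 nM in this assay, at which 1 of the 4 values shown sits.

The compounds shown do not separate the loss of chlorine and fluorine from the added stereocentre. A benzyl group or an unsubstituted phenyl on the same nitrogen would help divide the two.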